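Methoxy for hydrogen on the outer phenyl ring

The source may hold more compounds than are shown below. What is called first, only, known or untested is meant among the compounds shown, and "the series" means these compounds.

Measured compounds:
Compound 1, `COc1ccc(-c2nc(C)c(C(=O)CSc3nc(-c4ccc(Cl)cc4)c(C#N)c(=O)[nH]3)s2)cc1`: 92.7%
Compound 2, `COc1ccc(-c2nc(C)c(C(=O)CSc3nc(-c4ccc(OC)cc4)c(C#N)c(=O)[nH]3)s2)cc1`: 80.3%
Compound 3, `Cc1nc(-c2ccccc2)sc1C(=O)CSc1nc(-c2cccc(Cl)c2)c(C#N)c(=O)[nH]1`: 83.7%

In a functional assay on U-87MG ATCC cells for antiproliferative activity against U-87 MG (Homo sapiens), read by MTT assay, with a stated time of 48 h, tested at 10 uM (a higher number here means a weaker effect of the compound at the concentration tested, a lower number a stronger effect), compound 3 stands second highest of the three numbers. Its nearest neighbour is compound 2, whose value in this assay, 80.3%, lies within the scatter of compound 3; the furthest is compound 1, whose value, 92.7%, also lies within the scatter of compound 3, so no order among the three can be read from these values alone.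

Compound 4, `COc1ccc(-c2nc(C)c(C(=O)CSc3nc(-c4cccc(Cl)c4)c(C#N)c(=O)[nH]3)s2)cc1`, differs from compound 3 in one place: methoxy in place of hydrogen on an aromatic carbon.

Among the compounds with values here, no measured step matches this change. Within the data shown here, the only step among the measured compounds, a number 12.4 percentage points lower from compound 1 to compound 2 (beyond the scatter), concerns an exchange of one group for another on a different ring, and it is modest. It therefore gives no direct guidance on adding methoxy where hydrogen stood, and in the absence of a matching step the expectation for this assay is a step of no size beyond the scatter from compound 3. Compound 4 is accordingly expected to give about 84% in this assay, with a range from 70% to 96%, which means an expected step of a number 0.3 percentage points higher from compound 3 to compound 4 (within the scatter).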

Compound 4, a percentage reported as activity, at one concentration (the size of the read-out at that concentration, not a potency): 90.6%
Compound 4: middle estimate off by 6.6 percentage points, on the low side; measured number inside the range.
By their numbers in this assay, from the lowest: compounds 2, 3, 4 and 1 (each within the scatter of the next, the first and the last beyond it).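

Within the data shown here, on the outer phenyl ring, at the carbon para to a large group, the change from phenyl to 4-methoxyphenyl gives a number 6.9 percentage points higher from compound 3 to compound 4 (within the scatter) in this assay and so does not separate the two compounds, which is the first reading of a change on this ring. On the other ring, moving from the 4-chlorophenyl to the 3-chlorophenyl group with the outer ring held as 4-methoxyphenyl gives a number 2.1 percentage points lower from compound 1 to compound 4 (within the scatter) and likewise does not separate the compounds. By contrast, 3-chlorophenyl in place of 4-methoxyphenyl on that ring gives a number 10.3 percentage points higher from compound 2 to compound 4 (beyond the scatter) and so repeats, with a second chlorophenyl compound, the modest separation of compound 2 seen earlier.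

As far as these compounds go, whether a hydroxyl, an amine or a carboxylic acid at the para carbon of the outer ring would read any differently from hydrogen or methoxy remains open, as does whether the methoxy addition behaves the same way when the other ring carries a different group. From the compounds shown here alone, each value is also a read-out at a single concentration, so how these compounds rank in potency stays unknown. Nothing available accounts for any of these steps.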